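The source may report more compounds than this note shows. Statements on the series, on what has been measured and on what is new or still open speak of the compounds shown alone.

Of the compounds shown here, two of the shared core have been measured. Compound 1 `N=C(N)c1ccc(/N=N/Nc2cccc(C#Cc3ccccn3)c2)cc1` gives 10400 nM in a functional assay on PC-3 cells (Homo sapiens) for antiproliferative activity, read by WST assay, with a stated time of 72 h (a higher number here means a weaker inhibitor of growth, a lower number a stronger inhibitor of growth), the lower of the two numbers. Compound 2 `C#Cc1ccc(N/N=N/c2ccc(C(=N)N)cc2)cc1` gives 22500 nM in this assay, a number that lies beyond the scatter from compound 1. Among the compounds with values here, no step between measured compounds is recorded, so the move to the next compound rests on these two values alone. Compound 3 `COc1ccc(C#Cc2cccc(N/N=N/c3ccc(C(=N)N)cc3)c2)cc1` differs from compound 1 by 4-methoxyphenyl in place of pyridin-2-yl on a triple-bonded carbon. The aryl group on the triple-bonded carbon is thus retained. Since compound 1 with an aryl on the triple-bonded carbon gives 10400 nM while compound 2 without one gives 22500 nM, an aryl at that place appears favourable. The change is therefore expected to shift the number little, if anything downward, with a 1.4-fold lower number from compound 1 to compound 3 (0.14 log units; within the scatter) expected to remain within the scatter. Compound 3 is estimated at 7500 nM, in the range 3000 nM to 18000 nM.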

Compound 3, concentration for 50% growth inhibition: 5000 nM
For compound 3 the middle estimate is 1.5-fold (0.18 log units) above the measured one; the range from low to high includes it.
By their numbers in this assay, from the lowest: compound 3; then compound 1; then compound 2.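

With 4-methoxyphenyl in place of pyridin-2-yl on the triple-bonded carbon, this assay shows a 2.1-fold lower number from compound 1 to compound 3 (0.32 log units; beyond the scatter) as a modest step. The number at this place therefore depends on which aryl group is carried there, but the step replaces a ring with one hetero atom by a ring of carbon only and adds the methoxy group at the same time, so the two parts cannot be separated. No measurement on hand accounts for the shift.

Open, as far as these compounds go, is how much of the step belongs to the methoxy group and how much to the loss of the ring nitrogen, which unsubstituted phenyl on the same carbon would help to divide. Also open, from the compounds shown here alone, is whether another group at the 4-position of that ring, such as an amine or a carboxylic acid, would move the number further.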